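Removing the Methyl from the Phenol Ether of Compound 3

The source may report more compounds than this note shows. Statements on the series, on what has been measured and on what is new or still open speak of the compounds shown alone.

Compound 1 `COc1ccc2[nH]c(-c3ccc[se]3)cc(=O)c2c1OC` gives > 100000 nM, which is a limit.
Compound 2 `COc1ccc2[nH]c(-c3ccc[se]3)cc(=O)c2c1O` gives 700 nM.
Compound 3 `COc1ccc2[nH]c(-c3ccc(C)[se]3)cc(=O)c2c1OC` gives > 50000 nM, which is also a limit.

All three numbers come from a functional assay on Hep 3B2 cells (Homo sapiens) for cytotoxicity, read by MTT assay, with a stated time of 48 h; on this read-out lower numbers stand for stronger inhibition and higher numbers for weaker inhibition. As far as these compounds go, compound 3 stands only at a limit, so its real number is unknown, and the step that the two limits leave unreadable from compound 1 to compound 3 cannot be read either. Compound 4 `COc1ccc2[nH]c(-c3ccc(C)[se]3)cc(=O)c2c1O` differs from compound 3 by hydrogen in place of methyl on an oxygen on an aromatic ring. The same change appears once among the measured compounds: an at least 140-fold lower number from compound 1 to compound 2 (2.15 log units; beyond the scatter), a large move toward stronger inhibition, although it starts from a limit of > 100000 nM in this assay, at which 1 of the 3 values shown sits, and is itself only a bound. A step in the same direction is therefore expected, an at least 50-fold lower number from compound 3 to compound 4 (1.69 log units; beyond the scatter), with the limit at compound 3 the limit of > 50000 nM in this assay, at which 1 of the 3 values shown sits, leaving its size uncertain. Compound 4 is estimated at 1000 nM, within 200 nM to 10000 nM.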

Compound 4, half-maximal inhibitory concentration: 800 nM
The estimate for compound 4 lay 1.3-fold (0.10 log units) above the measured number; low and high end bracket the measured number.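

In this assay, the change from methoxy to hydroxy gives an at least 62-fold lower number from compound 3 to compound 4 (1.79 log units; beyond the scatter), so the large move now appears on a second core and no longer rests on a single pair: the same change on two cores in this assay, an at least 140-fold lower number (2.15 log units; beyond the scatter) from compound 1 to compound 2 and an at least 62-fold lower number (1.79 log units; beyond the scatter) from compound 3 to compound 4; the limit leaves it open whether they differ

With the hydroxy in place, the methyl on the aromatic carbon can finally be read, and the result is a 1.1-fold higher number from compound 2 to compound 4 (0.06 log units; within the scatter), so compound 2 and compound 4 cannot be told apart.

An ethyl on that oxygen, or an amine in place of the hydroxy, remains an open question. So does a longer chain in place of the methyl on the aromatic carbon.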